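The source may report more compounds than this note shows. Statements on the series, on what has been measured and on what is new or still open speak of the compounds shown alone.

Measured compounds:
- compound 1 `CNC(=O)c1cc(C(=O)NC2CC2)cn(Cc2nccc3[nH]ccc23)c1=O`: 1.7
- compound 2 `CNC(=O)c1cc(C(=O)NC2CCC2)cn(Cc2cccnc2)c1=O`: 1.8
- compound 3 `CNC(=O)c1cc(C(=O)NCCOC)cn(Cc2ccccc2)c1=O`: 2.7

In a physicochemical assay for lipophilicity, at pH 7.4 (a higher number here means a more lipophilic compound, a lower number a more polar compound), compound 1 gives the lowest of the three numbers. Compound 2 gives 1.8, within the scatter of compound 1; compound 3 gives 2.7, beyond it.

Compound 4 `CNC(=O)c1cc(C(=O)NC2CC2)cn(Cc2cccc3occc23)c1=O` is not yet measured. It differs from compound 1 in one place: a group of 9 heavy atoms (8 carbon, 1 oxygen; one five-membered aromatic ring with 1 hetero atom, one six-membered aromatic ring of carbon only) in place of a group of 9 heavy atoms (7 carbon, 2 nitrogen; one five-membered aromatic ring with 1 hetero atom, one six-membered aromatic ring with 1 hetero atom), on a saturated chain carbon bound to an aromatic nitrogen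

Among the compounds with values here, no measured pair isolates this change, so its size must be guessed from the series. A hydrogen-bond donor and a ring nitrogen leave, and a carbon-only six-membered ring enters. In this assay an upward step beyond the scatter is therefore expected, a number 1.40 log units higher from compound 1 to compound 4 (beyond the scatter). Compound 4 is estimated at 3.1, with a range from 2.6 to 3.6.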

Compound 4, distribution coefficient: 3.4
Compound 4: middle estimate off by 0.30 log units, on the low side; the range from low to high includes it.
By their numbers in this assay, from the lowest: compounds 1 and 2 (each within the scatter of the next); then compound 3; then compound 4.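

In this assay, within the data shown here, placing 1-benzofuran-4-yl on the saturated chain carbon bound to an aromatic nitrogen gives a number 1.70 log units higher from compound 1 to compound 4 (beyond the scatter) with the rest of compound 1 unchanged, the first reading of this position in isolation. The number at this place is therefore far from fixed by the shared core. The exchange alters the hetero atoms and removes the hydrogen-bond donor together, and nothing available accounts for the size of the step. As far as these compounds go, how much each of these changes contributes remains open. Also open, from the compounds shown here alone, is where the number would fall with an amine or a carboxylic acid on the 1-benzofuran-4-yl group.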